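The source may hold more compounds than are shown below. What is called first, only, known or untested is meant among the compounds shown, and "the series" means these compounds.

Working notes on the series. The shared core is that of compound 2 `C#Cc1cn([C@@H]2O[C@H](CO)[C@@H](O)[C@H]2O)c2ncnc(OC)c12`, a methoxy-bearing bicyclic base carrying the sugar and an ethynyl group. Among the measured compounds shown here, in a functional assay on HepG2 cells (Homo sapiens) for antiproliferative activity, read by XTT assay, with a stated time of 72 h (a lower number here means a stronger inhibitor, a higher number a weaker inhibitor), compound 2 gives 12700 nM, the higher of the two numbers measured so far. Compound 3 `COc1ncnc2c1c(-c1ccsc1)cn2[C@@H]1O[C@H](CO)[C@@H](O)[C@H]1O` replaces the ethynyl with thiophen-3-yl, and in this assay compound 3 gives 430 nM. For the measured compounds named here, that single change is the only measured step: a 30-fold lower number from compound 2 to compound 3 (1.47 log units; beyond the scatter). Compound 1 `COc1nc(N)nc2c1c(-c1cc3ccccc3o1)cn2[C@@H]1O[C@H](CO)[C@@H](O)[C@H]1O` carries both an amino group and a benzofuranyl group. In this assay compound 1 reaches only the assay limit, > 20000 nM, and this is a limit, not a number (the limit of > 20000 nM in this assay, at which 1 of the 3 values shown sits).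

Compound 4 `C#Cc1cn([C@@H]2O[C@H](CO)[C@@H](O)[C@H]2O)c2nc(N)nc(OC)c12` keeps the ethynyl of compound 2 and adds the amino group: amino in place of hydrogen on an aromatic carbon. Going by the values given here, no measured step isolates this change; the one step measured concerns the aryl group, not the amino group, and compound 1 differs from compound 3 in two places, so their two values show only that the amino-bearing member sits at the limit. An upward move in this assay is therefore expected, of uncertain size. The expected step is a 1.4-fold higher number from compound 2 to compound 4 (0.15 log units; within the scatter). For compound 4 in this assay the estimate is 18000 nM, within 6000 nM to 40000 nM.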

Compound 4, half-maximal inhibitory concentration: > 20000 nM
Compound 4 was reported as a limit; the forecaster's own chance of this, stated with the estimate: 45%; middle value at least 1.1-fold (0.04 log units) from the limit.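

In this assay, among the compounds shown here, the amino group on the aromatic carbon between two ring nitrogen atoms now has a step of its own, an at least 1.5-fold higher number from compound 2 to compound 4 (0.19 log units; that floor lies within the scatter), whereas the earlier compounds showed it only together with a second difference. Compound 4 is reported as a limit, > 20000 nM, so this step is only a floor; that floor does not separate the amino compound from its hydrogen counterpart, but amino in place of hydrogen gives no sign of a lower number on the ethynyl compound. The step between the two amino-bearing compounds, which differ in ethynyl and 1-benzofuran-2-yl, cannot be read, and both sit at the same limit: the limit of > 20000 nM in this assay, at which 2 of the 4 values shown sit.

Going by these compounds, how far the true value of compound 4 lies past the limit remains open. Open too, on these data alone, is whether amino in place of hydrogen would move the number on compound 3, whose readable value of 430 nM leaves room to see a change. Also open, as far as these compounds go, is how a methyl group or a hydroxyl group on the same aromatic carbon would compare with hydrogen and amino.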